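Dichlorophenyl replacement on the shared core

The source may hold more compounds than are shown below. What is called first, only, known or untested is meant among the compounds shown, and "the series" means these compounds.

Measured in a functional assay on HCT-116 cells (Homo sapiens) for inhibition, read by sulforhodamine B assay, with a stated time of 72 h; a lower number here means a stronger inhibitor, a higher number a weaker inhibitor:
compound 1 `CC(c1ccc(-c2ccccc2)c(F)c1)c1nnc2n1N=C(c1ccc(OC(F)(F)F)cc1)CS2`: 5400 nM
compound 2 `CC(C)Cc1ccc(C(C)c2nnc3n2N=C(c2ccc(C(F)(F)F)cc2)CS3)cc1`: 6500 nM
compound 3 `CC(c1ccc(-c2ccccc2)c(F)c1)c1nnc2n1N=C(c1ccc([N+](=O)[O-])cc1)CS2`: 7100 nM

Compound 2 sits among the three values, with compound 3 nearest and compound 1 furthest; both gaps are within the scatter, so the three compounds are not separated in this assay.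

Compound 4 `CC(C)Cc1ccc(C(C)c2nnc3n2N=C(c2ccc(Cl)cc2Cl)CS3)cc1` differs from compound 2 by 2,4-dichlorophenyl in place of 4-(trifluoromethyl)phenyl on a carbon with a double bond to nitrogen. For the measured compounds named here, the only measured step at this carbon, a 1.3-fold higher number from compound 1 to compound 3 (0.12 log units; within the scatter), exchanges one aryl substituent for another on a different left-hand side and stays within the scatter. Going by the values given here, no measured pair shows a dichlorophenyl. On that basis the step of a 1.1-fold lower number from compound 2 to compound 4 (0.03 log units; within the scatter) is expected to stay within the scatter, with no direction beyond it. Compound 4 is therefore estimated at 6000 nM, with a range from 2500 nM to 15000 nM.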

Compound 4, half-maximal inhibitory concentration: 11100 nM
For compound 4 the middle estimate is 1.9-fold (0.27 log units) below the measured one; the range from low to high includes it.
By their numbers in this assay, from the lowest: compounds 1, 2, 3 and 4 (each within the scatter of the next, the first and the last beyond it).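

In this assay, the pair with a dichlorophenyl on the carbon with a double bond to nitrogen gives a 1.7-fold higher number from compound 2 to compound 4 (0.23 log units; within the scatter). With a 1.3-fold higher number from compound 1 to compound 3 (0.12 log units; within the scatter), both aryl exchanges at this carbon, made on two different left-hand sides, stay within the scatter, so this position has not yet separated any pair. No measurement on hand bears on the reason for the size of this step.

Open, as far as these compounds go, is whether an amine or a carboxylic acid on this aryl ring would move the number beyond the scatter. Also open, from the compounds shown here alone, is whether 2,4-dichlorophenyl gives a similar step on the left-hand side of compound 1.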